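The source may hold more compounds than are shown below. What is called first, only, known or untested is meant among the compounds shown, and "the series" means these compounds.

Compound 1 `N#C/C(=C\c1ccc[nH]1)C(=O)NCc1ccc(Cl)c(Cl)c1` reaches only the limit of > 50000 nM in a functional assay on SJ-G2 cells (Homo sapiens) for inhibition, read by MTT assay, with a stated time of 72 h (a lower number here means a stronger inhibitor of growth, a higher number a weaker inhibitor of growth), so no number is known for it. Compound 2 `COc1ccc(CNC(=O)/C(C#N)=C/c2ccc(C)o2)cc1` gives 75000 nM in this assay, the only plain number shown. The only other entry is the limit of > 50000 nM in this assay, at which 1 of the 2 values shown sits. Compound 3 `COc1ccc(CNC(=O)/C(C#N)=C/c2ccc(Cl)cc2)cc1` differs from compound 2 in one place: 4-chlorophenyl in place of 5-methylfuran-2-yl on a double-bonded chain carbon bound to a double-bonded chain carbon. Among the compounds with values here, with no measured step between two numbers to lean on, the expected step of a 1.3-fold lower number from compound 2 to compound 3 (0.10 log units; within the scatter) stays within the usual scatter, in neither direction. Compound 3 is therefore estimated at 60000 nM, between 20000 nM and 150000 nM, and the assay may again report only a limit.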

Compound 3, concentration for 50% growth inhibition: 11000 nM
Compound 3: middle estimate off by 5.5-fold (0.74 log units), on the high side, and the stated range ends above it.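

Within the data shown here, this position on the shared core clearly matters for growth inhibition: putting 4-chlorophenyl in place of 5-methylfuran-2-yl on a double-bonded chain carbon bound to a double-bonded chain carbon gives a 6.8-fold lower number from compound 2 to compound 3 (0.83 log units; beyond the scatter) in this assay, the first comparison here between two plain numbers. Nothing shown measures why the new ring gives the lower number. This single step cannot separate the effect of the chlorine from that of the change of ring. From the compounds shown here alone, whether an amine or a carboxylic acid in this same place would give a lower or higher number stays open.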